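Replacing an amino group with methyl on a chromane-like core

The source may report more compounds than this note shows. Statements on the series, on what has been measured and on what is new or still open speak of the compounds shown alone.

Measured compounds:
compound 1, `CC(C)CN(c1ccc(N(C)C)cc1)S(=O)(=O)c1ccc2c(c1)C(O)CC(C1CCOCC1)O2`, a physicochemical assay for lipophilicity, at pH 7.4; on this read-out higher numbers stand for higher lipophilicity and lower numbers for lower lipophilicity: 3.51
compound 2, `CCc1ccc(N(CC(C)C)S(=O)(=O)c2ccc3c(c2)C(OC2CCCCC2)CC(C2CCOCC2)O3)cc1`, this assay: 6.28
compound 3, `CCc1ccc(N(CC(C)C)S(=O)(=O)c2ccc3c(c2)C(N)CC(C2CCOCC2)O3)cc1`, this assay: 3.08

Compound 3 stands lowest of the three numbers in this assay. Its nearest neighbour is compound 1, whose value is higher by an amount beyond the scatter, and its furthest is compound 2, well above it. Compound 4, `CCc1ccc(N(CC(C)C)S(=O)(=O)c2ccc3c(c2)C(C)CC(C2CCOCC2)O3)cc1`, has not yet been measured; it differs from compound 3 in one place: methyl in place of amino on a saturated ring carbon.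

For the measured compounds named here, one measured step touches the same position. The step of a number 3.20 log units lower from compound 2 to compound 3 (beyond the scatter) shows how far the number fell when the amino group came in for cyclohexyloxy. That step does not isolate the amino-to-methyl exchange itself. Its leaving group was cyclohexyloxy, not methyl, so the direction is the better guide than the size. Compound 1, with a hydroxyl at that position and a different aryl substituent, offers no single-change comparison to compound 3 and is used only for orientation.

For compound 4 an upward step in this assay is expected, a number 1.82 log units higher from compound 3 to compound 4 (beyond the scatter), clearly beyond the scatter but smaller than the drop seen from compound 2. Compound 4 is therefore estimated at 4.9, with a range from 4.2 to 5.6.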

Compound 4, distribution coefficient: 5.71
Estimate against measurement, compound 4: 0.81 log units below; measured number outside the range, above it.
By their numbers in this assay, from the lowest: compound 3; then compound 1; then compound 4; then compound 2.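

In this assay the exchange of amino for methyl on this saturated ring carbon gives a number 2.63 log units higher from compound 3 to compound 4 (beyond the scatter) and counts as a large step, so swapping one nitrogen for one carbon, with the loss of the hydrogen-bond donor and acceptor counted for amino, moves this read-out strongly on its own. Methyl in place of the much larger cyclohexyloxy gives only a number 0.57 log units lower from compound 2 to compound 4 (beyond the scatter) and counts as a modest step, so at this position the single-atom methyl stands far closer to cyclohexyloxy than to amino, even though it has just one heavy atom. Amino therefore stands apart from both other groups at this carbon in the compounds that differ only here, a separation that the fall from cyclohexyloxy to amino alone could not show. Nothing available here explains why the numbers fall in this order.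

On these data alone, whether a dimethylamino group or a carboxylic acid at this carbon would stay near amino, and whether a methoxy group would stay near methyl, remains open. Also open, as far as these compounds go, is whether the same exchange would give a step of similar size on the core of compound 1, which carries a dimethylamino group on its aryl ring.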